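This account rests on a few compounds, and the source may have more. Where it says the series, first, only, none or still open, it means among the compounds named here.

Working notes on the series, read in a functional assay on HUVEC cells (Homo sapiens) for antiproliferative activity, read by MTT assay, with a stated time of 24 h; a higher number here means a weaker inhibitor, a lower number a stronger inhibitor.

Compound 1 `C=CCOc1ccc2c(=O)c(-c3cc(OC)c(OC)cc3OC)coc2c1` opens the set. In this assay compound 1 gives > 10000 nM, which is a limit of the assay and not a number. Within the data shown here, compound 2 `COc1ccc2c(=O)c(-c3cc(OC)c(OC)cc3OC)coc2c1` is the second entry, and the one recorded step, a step that the two limits leave unreadable from compound 1 to compound 2, links the two. In this assay compound 2 gives > 10000 nM, again a limit rather than a number. Among the measured compounds shown here, compound 2 thus stands at the limit together with the only other measured compound, as the limit of > 10000 nM in this assay, at which 2 of the 2 values shown sit, records; no readable step exists, so nothing yet shows how the group on this oxygen of the shared core moves potency.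

Compound 3 `COc1cccc(C(=O)Oc2ccc3c(=O)c(-c4cc(OC)c(OC)cc4OC)coc3c2)c1` is the next entry. Its change from compound 2 is (3-methoxyphenyl)carbonyl in place of methyl on an oxygen on an aromatic ring. For the measured compounds named here, no measured step bears on this change, and the single step recorded is itself unreadable between two limits. The expectation for compound 3 therefore rests only on the limit where compound 2 sits and carries a wide range. Compound 3 is expected to show a step that the limit leaves unreadable from compound 2 to compound 3 in this assay. Compound 3 is estimated at 12000 nM, with a range from 2500 nM to 60000 nM, and a report of only a limit is the likelier outcome.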

Compound 3, half-maximal inhibitory concentration: > 10000 nM
Compound 3: only a limit was reported; the forecaster's own chance of this, stated with the estimate: 60%; the middle value is on the limit's open side.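

In this assay compound 3 gives > 10000 nM which is a limit of the assay and not a number, so the steps to compound 3 from compound 1 and from compound 2 cannot be read. The compounds shown leave open whether any group on this oxygen of the shared core moves potency, as all three sit at one value: the limit of > 10000 nM in this assay, at which 3 of the 3 values shown sit.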